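Alkylidene sulfone series: cytotoxicity on K562 cells

The source may hold more compounds than are shown below. What is called first, only, known or untested is meant among the compounds shown, and "the series" means these compounds.

Measured compounds:
compound 1 `COC(=O)CNc1cc(CS(=O)(=O)/C=C/c2cc(OC)c(OC)c(OC)c2)ccc1OC`: 30000 nM
compound 2 `COC(=O)C(Nc1cc(CS(=O)(=O)/C=C/c2c(OC)cc(OC)cc2OC)ccc1OC)c1ccccc1`: 30 nM

In a functional assay on K562 cells (Homo sapiens) for cytotoxicity, read by trypan blue exclusion, with a stated time of 96 h (on this read-out higher numbers stand for weaker inhibition and lower numbers for stronger inhibition), compound 2 gives 30 nM and compound 1 gives 30000 nM. Compound 2 thus stands at the lowest of the two numbers, well beyond the scatter from compound 1; the two differ in several places at once, so their values alone are noted here.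

Compound 3 `COc1cc(OC)c(/C=C/S(=O)(=O)Cc2ccc(OC)c(NC(C(=O)O)c3ccc(F)cc3)c2)c(OC)c1` is the next compound, not yet measured. It differs from compound 2 in one place: carboxy(4-fluorophenyl)methyl in place of methoxycarbonyl)(benzyl on a nitrogen on an aromatic ring. The methoxycarbonyl is replaced by a carboxy group and a fluorine is added to the ring that enters; the core and the sulfone link are unchanged.

Going by the values given here, no step between measured compounds shows the effect of such a change. Since compound 2 gives 30 nM and compound 3 keeps the whole core, a modest weakening beyond the scatter is expected, about a 3.3-fold higher number from compound 2 to compound 3 (0.52 log units; beyond the scatter) in this assay. Compound 3 is therefore estimated at 100 nM, with a range from 20 nM to 600 nM.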

Compound 3, half-maximal inhibitory concentration: 80 nM
Compound 3: middle estimate off by 1.3-fold (0.10 log units), on the high side, within the range that was stated.
By their numbers in this assay, from the lowest: compound 2; then compound 3; then compound 1.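

On the nitrogen on an aromatic ring, carboxy(4-fluorophenyl)methyl in place of methoxycarbonyl)(benzyl gives in this assay a 2.7-fold higher number from compound 2 to compound 3 (0.43 log units; beyond the scatter) as a modest step beyond the scatter, and compound 3 still gives 80 nM with the core and the sulfone link unchanged. Going by these compounds alone, this is the first reading at this position, and it shows that a carboxy group together with a fluorine on the ring keeps the value close to that of the methoxycarbonyl compound rather than producing a large loss. The two edits arrive in a single step and no measurement on hand accounts for the size of that step.

The compounds shown do not separate the share of the carboxy group from that of the fluorine, which would take the carboxy compound with an unsubstituted phenyl ring or the methoxycarbonyl compound with the 4-fluorophenyl ring. Going by these compounds, how a carboxamide or a hydroxymethyl group would read in place of the carboxy group at this position also remains open, as does a chlorine in place of the fluorine.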